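A few compounds are considered here, and "the series" means these few. Any claim that something is new, unique, unknown or untested is made for them only; others in the source may bear on it.

Measured in a functional assay on MCF7 cells (Homo sapiens) for cytotoxicity, read by ELISA, with a stated time of 4 days; a lower number here means a stronger inhibitor, a higher number a weaker inhibitor:
- compound 1 `Clc1ccc(-c2cc(-c3ccoc3)cc(-c3ccco3)n2)s1`: 4740 nM
- compound 2 `Cc1ccc(-c2cc(-c3ccoc3)cc(-c3ccc(Cl)s3)n2)cc1`: 5340 nM
- compound 3 `Clc1ccc(-c2cc(-c3ccco3)nc(-c3ccc(Cl)s3)c2)o1`: 16900 nM

Compound 3 has the highest number of the three, so it is the weakest inhibitor here. Compound 4 `Cc1ccc(-c2cc(-c3ccc(Cl)o3)cc(-c3ccc(Cl)s3)n2)cc1` differs from it by one change, 4-methylphenyl in place of furan-2-yl on an aromatic carbon. The same swap has been measured once, as a 1.1-fold higher number from compound 1 to compound 2 (0.05 log units; within the scatter). The other measured step, a 3.6-fold higher number from compound 1 to compound 3 (0.55 log units; beyond the scatter), introduced the 5-chlorofuran-2-yl group, which compound 4 shares with compound 3, so the higher level should persist. One earlier example is thin evidence, but no change beyond the scatter is expected in this assay. The expected result is a 1.2-fold lower number from compound 3 to compound 4 (0.08 log units; within the scatter). The estimated value for compound 4 is 14000 nM, with an expected range of 6500 nM to 30000 nM.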

Compound 4, half-maximal inhibitory concentration: 3040 nM
For compound 4 the middle estimate is 4.6-fold (0.66 log units) above the measured one; the whole stated range lies above it.
By their numbers in this assay, from the lowest: compounds 4, 1 and 2 (each within the scatter of the next); then compound 3.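

Placing 4-methylphenyl in place of furan-2-yl next to the ring nitrogen gave a 5.6-fold lower number from compound 3 to compound 4 (0.75 log units; beyond the scatter) in this assay, so this change has no single size across the two cores: the same change on two cores in this assay, a 1.1-fold higher number (0.05 log units; within the scatter) from compound 1 to compound 2 and a 5.6-fold lower number (0.75 log units; beyond the scatter) from compound 3 to compound 4, 6.3-fold (0.80 log units) apart, beyond the scatter of two such steps. The swap of furan-3-yl for 5-chlorofuran-2-yl likewise differs between cores, with a 1.8-fold lower number from compound 2 to compound 4 (0.24 log units; within the scatter) where 4-methylphenyl is present: the same change on two cores in this assay, a 3.6-fold higher number (0.55 log units; beyond the scatter) from compound 1 to compound 3 and a 1.8-fold lower number (0.24 log units; within the scatter) from compound 2 to compound 4, 6.3-fold (0.80 log units) apart, beyond the scatter of two such steps. Thus the effect of each group depends on the other.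

Four compounds cannot show how general this dependence is. Going by these compounds, how an amine or a carboxylic acid next to the ring nitrogen would behave remains open.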